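The compounds below may be only part of what the source reports. "The series", "measured", "known", "first", "only" and "open" are said of these compounds alone.

Measured so far in a functional assay on cells for antagonist activity at C-C chemokine receptor type 4 (Homo sapiens), read by GTPgammaS binding; a lower number here means a stronger inhibitor, a higher number a weaker inhibitor:
- compound 1, `COc1nn(C)c2nc(C)nc(NS(=O)(=O)c3cccc(Cl)c3Cl)c12`, gives 631 nM
- compound 2, `COc1nn(C)c2nc(N)nc(NS(=O)(=O)c3cccc(Cl)c3Cl)c12`, gives 316 nM

For the measured compounds named here, compound 2 holds the lower of the two numbers in this assay, but the only step between measured compounds, a 2.0-fold lower number from compound 1 to compound 2 (0.30 log units; within the scatter), lies within the scatter, so the two compounds are not separated.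

Compound 3, `CCNc1nc(NS(=O)(=O)c2cccc(Cl)c2Cl)c2c(OC)nn(C)c2n1`, differs from compound 2 by ethyl in place of hydrogen on a nitrogen on an aromatic ring. Going by the values given here, no measured step bears directly on this change: the single step available concerns an amino in place of a methyl on an aromatic carbon, a different position, and was itself within the scatter. The series gives no ground for expecting a shift beyond the scatter in either direction, so the step from compound 2 to compound 3 is expected to be about a 1.1-fold lower number from compound 2 to compound 3 (0.02 log units; within the scatter).

Compound 3 is estimated at 300 nM in this assay, with a range from 100 nM to 1000 nM.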

Compound 3, half-maximal inhibitory concentration: 251 nM
Compound 3: the middle estimate sits 1.2-fold (0.08 log units) above what was measured; low and high end bracket the measured number.
By their numbers in this assay, from the lowest: compounds 3, 2 and 1 (each within the scatter of the next, the first and the last beyond it).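

In this assay, ethyl in place of hydrogen on a nitrogen on an aromatic ring is tolerated: a 1.3-fold lower number from compound 2 to compound 3 (0.10 log units; within the scatter) leaves the two compounds unseparated, so this nitrogen carries an ethyl with no readable loss. Ethylamino in place of methyl on an aromatic carbon gives the first step in the series beyond the scatter, a 2.5-fold lower number from compound 1 to compound 3 (0.40 log units; beyond the scatter), though a modest one, whereas amino in place of the same methyl stayed within it. No measurement at hand accounts for either step.

Open, going by these compounds, is whether a longer chain such as propyl or a branched one such as isopropyl on this nitrogen would separate from compound 2. Also open, on these data alone, is how a second ethyl on the same nitrogen, or a cyclic amine such as morpholine in its place, would read.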